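The source may report more compounds than this note shows. Statements on the series, on what has been measured and on what is new or still open speak of the compounds shown alone.

In an ADME assay on MT4 cells (Homo sapiens) for cytotoxicity, read by MTT assay, with a stated time of 96 h (a lower number here means that less compound is tolerated, a higher number that more compound is tolerated), compound 1 (`Clc1cccc(/N=N/N2CCCC2)c1`) gives > 100000 nM, which is a limit and not a number. Compound 2 (`Clc1ccc(/N=N/N2CCCC2)cc1`) gives > 100000 nM, which is also a limit. Compound 2 therefore stands at the limit of > 100000 nM in this assay, at which 2 of the 2 values shown sit. Compound 3 (`Clc1ccc(/N=N/N2CCCC2)cc1Cl`) differs from compound 2 by chloro in place of hydrogen on an aromatic carbon, with chloro in place of hydrogen on an aromatic carbon. Among the measured compounds shown here, no measured step covers this kind of change, so in this assay only a small shift to a lower number is expected, possibly none beyond the scatter. The expected step is an at least 1.4-fold lower number from compound 2 to compound 3 (0.15 log units; that floor lies within the scatter). For compound 3 the estimated value is 70000 nM, with an expected range of 25000 nM to 100000 nM.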

Compound 3, half-maximal cytotoxic concentration: 75000 nM
Estimate against measurement, compound 3: 1.1-fold (0.03 log units) below; low and high end bracket the measured number.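

In this assay, among the compounds shown here, chloro in place of hydrogen on an aromatic carbon, ortho to a chloro group, gives compound 3 the first actual number of the series, 75000 nM. The change reads as an at least 1.3-fold lower number from compound 2 to compound 3 (0.12 log units; that floor lies within the scatter), and as an at least 1.3-fold lower number from compound 1 to compound 3 (0.12 log units; that floor lies within the scatter). The true size of each step stays unknown because both starting compounds sit at a limit: the limit of > 100000 nM in this assay, at which 2 of the 3 values shown sit.

On these data alone, whether an amine or a carboxylic acid on this aromatic carbon would leave the number in the same range remains open.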